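The source may hold more compounds than are shown below. What is called first, only, known or untested is meant among the compounds shown, and "the series" means these compounds.

Three compounds have been measured in an assay on CV-1 cells for activation of retinoic acid receptor beta (Homo sapiens); a higher number here means that more compound is needed for the effect, a lower number that less compound is needed:
compound 1, `CC(/C=C/C=C(\C)c1ccc2c(c1)C(C)(C)CCO2)=C\C(=O)O`, gives 72 nM;
compound 2, `CC(/C=C/C=C(\C)c1ccc2c(c1)C(C)(C)CCS2)=C\C(=O)O`, gives 43 nM;
compound 3, `C/C(=C\c1ccc(C(=O)O)cc1)c1ccc2c(c1)C(C)(C)CCO2`, gives 190 nM.

Among these three numbers compound 3 stands highest. Its nearest neighbour is compound 1, whose number is lower by a gap beyond the scatter, and compound 2 lies further below it, again beyond the scatter. For the measured compounds named here, no two of the measured compounds differ in only one place, so no single step has been measured directly.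

Compound 4, `COC(=O)c1ccc(/C=C(\C)c2ccc3c(c2)C(C)(C)CCO3)cc1`, is the next compound to be measured in this assay. It differs from compound 3 in one place: methyl in place of hydrogen on an oxygen next to a carbonyl group, which, read one bond further out, is carboxy to methoxycarbonyl. Going by the values given here, since no measured pair shows this change, its size can only be expected, not read off. The author expects the number to rise, by a step of a 7.9-fold higher number from compound 3 to compound 4 (0.90 log units; beyond the scatter) that should lie beyond the scatter. Compound 4 is therefore estimated at 1500 nM, with a range from 300 nM to 8000 nM.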

Compound 4, half-maximal effective concentration: 140 nM
Compound 4: the middle estimate sits 11-fold (1.03 log units) above what was measured; the measured number lies below the stated range.
By their numbers in this assay, from the lowest: compounds 2, 1, 4 and 3 (each within the scatter of the next, the first and the last beyond it).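

Methyl in place of hydrogen on an oxygen next to a carbonyl group, read one bond further out as carboxy to methoxycarbonyl, gives a 1.4-fold lower number from compound 3 to compound 4 (0.13 log units; within the scatter) in this assay, so the two numbers cannot be told apart. For the compounds shown here, this is the first single change read directly in the set, and it shows that, in this pair, the hydrogen on this oxygen is not needed for a number of this size. The data shown offer no measurement that would explain this result.

The compounds shown leave open whether a longer chain on this oxygen, such as ethyl, or an amide in place of the carboxy group would also stay within the scatter. They also leave open whether methyl on this oxygen would behave the same way in compound 1 and compound 2.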